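Pyridine in place of a fluorinated ring on a sodium channel blocker

The source may report more compounds than this note shows. Statements on the series, on what has been measured and on what is new or still open speak of the compounds shown alone.

Of the compounds shown here, two built on a shared core have been measured in an assay on HEK293 cells for inhibition of SCN8A/SCN1B (Homo sapiens), read by patch clamp, with a stated time of 20 min; a higher number here means a weaker inhibitor, a lower number a stronger inhibitor. Compound 1, `C[C@H](Nc1cc(F)c(S(=O)(=O)Nc2nccs2)cc1Cl)c1ccc(F)cc1`, gives 230 nM. Within the data shown here, compound 2, `C[C@H](Nc1cc(F)c(S(=O)(=O)Nc2nccs2)cc1Cl)c1ccc(F)cc1F`, gives 40 nM, and among the two numbers so far it has the lowest one, with the step of a 5.8-fold lower number from compound 1 to compound 2 (0.76 log units; beyond the scatter) lying beyond the scatter. Compound 3, `C[C@H](Nc1cc(F)c(S(=O)(=O)Nc2nccs2)cc1Cl)c1cccnc1`, has not yet been measured. It differs from compound 2 in one place: pyridin-3-yl in place of 2,4-difluorophenyl on a saturated chain carbon bound to a nitrogen on an aromatic ring and a saturated chain carbon. Among the measured compounds shown here, no measured step swaps a whole ring in this way; the only step known, from compound 1 to compound 2, shows that putting a fluoro in place of hydrogen on that ring lowered the number. Compound 3 gives up both fluorines and brings in a ring nitrogen, so the most relevant guidance is that the fluorines helped compound 2, and taking them away is expected to push the number back up. The step of a 7.5-fold higher number from compound 2 to compound 3 (0.88 log units; beyond the scatter) is therefore expected to go toward a weaker inhibitor. For compound 3 the estimated value is 300 nM, with a plausible range from 80 nM to 1200 nM.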

Compound 3, half-maximal inhibitory concentration: 80 nM
Compound 3: the middle estimate sits 3.8-fold (0.57 log units) above what was measured, within the range that was stated.
By their numbers in this assay, from the lowest: compounds 2 and 3 (each within the scatter of the next); then compound 1.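

In this assay, the step of a 2.0-fold higher number from compound 2 to compound 3 (0.30 log units; within the scatter) shows that the 2,4-difluorophenyl group on a saturated chain carbon bound to a nitrogen on an aromatic ring and a saturated chain carbon can give way to pyridin-3-yl with no difference that can be told apart from repeat-measurement noise. The ring at this place therefore needs no fluorine to match compound 2, something the earlier fluoro step could not show, and the step of a 2.9-fold lower number from compound 1 to compound 3 (0.46 log units; beyond the scatter) sets pyridin-3-yl clearly apart from 4-fluorophenyl. Nothing available here bears on why the ring nitrogen can stand in for the two fluorines, so the result records an outcome and not a cause.

The compounds shown leave open how a plain phenyl ring would compare at this place, which would show what the fluorines and the ring nitrogen each contribute when set against a ring with neither. They also leave open whether the place of the ring nitrogen matters, as pyridin-2-yl or pyridin-4-yl would test, and whether a saturated ring such as piperidine would be accepted here.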